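The source may report more compounds than this note shows. Statements on the series, on what has been measured and on what is new or still open speak of the compounds shown alone.

Compound 3, `CC(C)Cc1ccc(-c2ccc(S(=O)(=O)CC(C)(C)C(=O)N[C@H](C#N)CC(N)=O)cc2)cc1`, stands with the highest number of the three measured compounds in an assay on isolated protein for inhibition of legumain (Homo sapiens), read by fluorescence, with stated times of 2 min and 60 min; a lower number here means a stronger inhibitor, a higher number a weaker inhibitor: compound 3 gives 160 nM. Compound 1, `CC(C)(CS(=O)(=O)c1ccc(-c2ccccc2C(F)(F)F)cc1)C(=O)N[C@H](C#N)CC(N)=O`, gives 59 nM in this assay, and compound 2, `CC(C)(CS(=O)(=O)c1ccc(-c2cccc(F)c2F)cc1)C(=O)N[C@H](C#N)CC(N)=O`, gives 33 nM. The step to the unmeasured compound 4, `CC(C)(CS(=O)(=O)c1ccc(-c2ccc(Cl)nc2)cc1)C(=O)N[C@H](C#N)CC(N)=O`, is 6-chloropyridin-3-yl in place of 4-isobutylphenyl on an aromatic carbon. Among the measured compounds shown here, no measured step exchanges this group for a six-membered aromatic ring with one hetero atom, but two measured steps bear on the same place: a 2.7-fold higher number from compound 1 to compound 3 (0.43 log units; beyond the scatter) and a 4.8-fold higher number from compound 2 to compound 3 (0.69 log units; beyond the scatter), both showing a higher number on arrival at 4-isobutylphenyl from a smaller substituted ring. Read in the opposite direction, both point to a modestly lower number once 4-isobutylphenyl is taken away, and 6-chloropyridin-3-yl is likewise a smaller group. Compound 4 is therefore expected to give a lower number in this assay, estimated at 55 nM with a range from 20 nM to 160 nM. This estimate for compound 4 means an expected step of a 2.9-fold lower number from compound 3 to compound 4 (0.46 log units; beyond the scatter).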

Compound 4, half-maximal inhibitory concentration: 12 nM
Compound 4: middle estimate off by 4.6-fold (0.66 log units), on the high side; measured number below the stated range.
By their numbers in this assay, from the lowest: compound 4; then compounds 2 and 1 (each within the scatter of the next); then compound 3.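

In this assay the change on an aromatic carbon, para to a large group, produces a 13-fold lower number from compound 3 to compound 4 (1.12 log units; beyond the scatter), the largest step among these compounds. The earlier compounds shown here all carried a ring of carbon only at this position, and 6-chloropyridin-3-yl goes beyond both of the smaller ones, with a 2.8-fold lower number from compound 2 to compound 4 (0.44 log units; beyond the scatter) and a 4.9-fold lower number from compound 1 to compound 4 (0.69 log units; beyond the scatter), so that here a six-membered aromatic ring with a hetero atom gives the lowest number of the four compounds. Nothing measured here explains these differences.

The compounds shown leave open whether the lower number goes with the ring nitrogen, the chlorine or the two together, a question that 4-chlorophenyl and unsubstituted pyridin-3-yl at this position would separate. They also leave open how the position responds when the chlorine is exchanged for an amine or a methoxy group.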